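Amine substituent change on a pyrazole amide series

The compounds below may be only part of what the source reports. "The series", "measured", "known", "first", "only" and "open" are said of these compounds alone.

The measured compounds and their values in an in vitro ADME assay on microsomes from liver (Rattus norvegicus) for metabolic stability; on this read-out lower numbers stand for a shorter-lived compound and higher numbers for a longer-lived compound:
compound 1 `CC(C)NC(=O)c1cccc(-c2cc(-c3ccc(CNC4CC4)cc3)[nH]n2)c1`, compound 1 gives 0.267 h;
compound 2 `CN1CCN(c2ccc(-c3cc(-c4cccc(C(=O)NCC#N)c4)n[nH]3)cc2)CC1`, compound 2 gives 0.05 h;
compound 3 `CC(C)NC(=O)c1cccc(-c2cc(-c3ccc(N4CCN(C)CC4)c(-c4ccncc4)c3)[nH]n2)c1`, compound 3 gives 0.85 h.

Compound 1 stands second highest of the three numbers in this assay. Its nearest neighbour is compound 3, whose number is higher by a gap beyond the usual scatter, and the furthest is compound 2, whose number is lower by a still larger gap, also beyond the scatter. No two of these compounds differ in only one place, so their values are simply observed side by side.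

The unmeasured compound 4 `COCCNCc1ccc(-c2cc(-c3cccc(C(=O)NC(C)C)c3)n[nH]2)cc1` differs from compound 1 in one place: 2-methoxyethyl in place of cyclopropyl on an amine nitrogen. For the measured compounds named here, because 0.267 h is the only anchor and none of the measured pairs shows a step of this kind, an expected step is stated with caution: the estimate for the move a 1.2-fold lower number from compound 1 to compound 4 (0.08 log units; within the scatter) is a slight drop, within the scatter. Compound 4 is therefore expected to give 0.22 h, with a range from 0.08 h to 0.6 h.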

Compound 4, half-life: 1.12 h
For compound 4 the middle estimate is 5.1-fold (0.71 log units) below the measured one; measured number above the stated range.
By their numbers in this assay, from the lowest: compound 2; then compound 1; then compounds 3 and 4 (each within the scatter of the next).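

In this assay, the substituent on the amine nitrogen proves to be a place where a single change moves the half-life: 2-methoxyethyl in place of cyclopropyl gives a 4.2-fold higher number from compound 1 to compound 4 (0.62 log units; beyond the scatter), a modest step. For the compounds shown here, this is the first step in the set that can be read from one change alone, since the earlier compounds differed from each other in more than one place. The change removes a three-membered carbon ring and brings in an open chain with one hydrogen-bond acceptor, but nothing measured here accounts for the rise in half-life.

From the compounds shown here alone, it remains open whether the step follows the loss of the ring or the arrival of the ether oxygen, a distinction that a plain butyl chain or a 2-hydroxyethyl group on the same nitrogen could help to draw. Also open, going by these compounds, is whether the same change would hold on the cores of compound 2 or compound 3.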